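The compounds below may be only part of what the source reports. "The series", "measured", "known", "first", "only" and "open" are said of these compounds alone.

Three compounds sharing one core differ only in the aryl group attached to a carbon with a double bond to nitrogen. Compound 1 `CN(C)CCn1cnnc1-c1cc(Oc2ccc(NC(=O)N/N=C/c3ccc(Cl)cc3Cl)cc2F)ccn1` carries a 2,4-dichlorophenyl there, and in a functional assay on A549 cells (Homo sapiens) for cytotoxicity, read by MTT assay, with a stated time of 72 h (a lower number here means a stronger inhibitor, a higher number a weaker inhibitor), compound 1 gives 810 nM. Compound 2 `CN(C)CCn1cnnc1-c1cc(Oc2ccc(NC(=O)N/N=C/c3ccccc3O[N+](=O)[O-])cc2F)ccn1` carries a 2-(nitrooxy)phenyl, and in this assay compound 2 gives 1200 nM. Compound 3 `CN(C)CCn1cnnc1-c1cc(Oc2ccc(NC(=O)N/N=C/c3ccc(F)cc3)cc2F)ccn1` carries a 4-fluorophenyl, and in this assay compound 3 gives 1790 nM, the highest of the three numbers. The steps between these compounds were a 1.5-fold higher number from compound 1 to compound 2 (0.17 log units; within the scatter), a 2.2-fold higher number from compound 1 to compound 3 (0.34 log units; beyond the scatter) and a 1.5-fold higher number from compound 2 to compound 3 (0.17 log units; within the scatter), so exchanging this aryl group has so far shifted the number only modestly. Compound 4 `CN(C)CCn1cnnc1-c1cc(Oc2ccc(NC(=O)N/N=C/c3cccc(Br)c3)cc2F)ccn1` makes one further exchange at the same place: 3-bromophenyl in place of 4-fluorophenyl on a carbon with a double bond to nitrogen. All three measured steps bear on this change, and none of them was large. The number for compound 4 is therefore expected to lie close to that of compound 3, with a 1.5-fold lower number from compound 3 to compound 4 (0.17 log units; within the scatter) as the estimated step. Compound 4 is estimated at 1200 nM in this assay, within an expected range of 500 nM to 3000 nM.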

Compound 4, half-maximal inhibitory concentration: 970 nM
Compound 4: the middle estimate sits 1.2-fold (0.09 log units) above what was measured; low and high end bracket the measured number.
By their numbers in this assay, from the lowest: compounds 1, 4, 2 and 3 (each within the scatter of the next, the first and the last beyond it).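

In this assay, 3-bromophenyl in place of 4-fluorophenyl on a carbon with a double bond to nitrogen gives a small step (a 1.8-fold lower number from compound 3 to compound 4 (0.27 log units; within the scatter)), and the steps from the other two compounds are small as well (a 1.2-fold lower number from compound 2 to compound 4 (0.09 log units; within the scatter)) (a 1.2-fold higher number from compound 1 to compound 4 (0.08 log units; within the scatter)). Among these compounds, compound 4 therefore lies within the scatter of all three earlier compounds, so this fourth aryl group, with its bromine, cannot be told apart from any of them, and the only gap beyond the scatter remains the one separating compound 1 from compound 3. Nothing available explains why these aryl groups give such similar numbers. The compounds shown leave open whether a phenyl ring carrying an amine or a carboxylic acid would stay within this narrow band. They also leave open what happens if a simple alkyl chain replaces the aryl ring altogether.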